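The source may report more compounds than this note shows. Statements on the series, on what has been measured and on what is new or still open speak of the compounds shown alone.

Compound 1, `N=C(N)c1ccc(-c2ccc(-c3cc(Cl)cc(Cl)c3)s2)s1`: in a functional assay on MOLT-4 cells (Homo sapiens) for inhibition, read by sulforhodamine B assay, with a stated time of 48 h (on this read-out higher numbers stand for weaker inhibition of growth and lower numbers for stronger inhibition of growth), compound 1 gives 1710 nM.
Compound 2, `COc1ccc(-c2ccc(-c3ccc(C(=N)N)o3)o2)cc1`: in this assay compound 2 gives 1200 nM.

Of the compounds shown here, two have been measured, and they share a layout of three rings in a row with an amidine at one end. Of the two numbers, compound 2 has the smaller one, but its gap to compound 1 is within the scatter of repeated measurements, so the two cannot be told apart on this evidence.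

Compound 3, `N=C(N)c1ccc(-c2ccc(-c3ccccc3)o2)o1`, has not yet been measured. It differs from compound 2 in one place:

hydrogen in place of methoxy on an aromatic carbon

Going by the values given here, no measured pair shows what this change does, so the step can only be guessed. Removing a small group at the far end of the molecule has, in the absence of any comparison, no known direction here, and the step from compound 2 to compound 3 is expected to be small, a 1.5-fold higher number from compound 2 to compound 3 (0.18 log units; within the scatter), not clearly beyond the scatter in either direction. Compound 3 is therefore estimated to give about 1800 nM, with a likely range from 700 nM to 4500 nM.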

Compound 3, concentration for 50% growth inhibition: 3310 nM
The estimate for compound 3 lay 1.8-fold (0.26 log units) below the measured number, within the range that was stated.
By their numbers in this assay, from the lowest: compounds 2, 1 and 3 (each within the scatter of the next, the first and the last beyond it).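

Removing the methoxy group from its place on the six-membered aromatic ring of carbon only, para to a large group, gives a 2.8-fold higher number from compound 2 to compound 3 (0.44 log units; beyond the scatter) in this assay. Going by these compounds alone, this is the first measured step that lies beyond the scatter, so this position is not indifferent to what it carries: the compound with methoxy has the lower number, which here stands for stronger inhibition of growth, although the step is only modest. Nothing available here explains the difference, so the result records what happens to the number and gives no reason for it.

The compounds shown leave open how other groups at this same position would compare with methoxy and hydrogen, such as a hydroxyl group, an amine, a chlorine atom or a longer chain like ethoxy. They also leave open whether the same swap would give a step of similar size and direction on the core of compound 1, since this one pair comes from a single core.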